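The source may report more compounds than this note shows. Statements on the series, on what has been measured and on what is new or still open speak of the compounds shown alone.

Measured compounds:
- compound 1, `O=c1c2ccccc2c(Cc2ccc(Cl)cc2)nn1CCNCCCCc1ccc(OCCCN2CCCCCC2)cc1`, in an assay for binding affinity to Alpha-1A adrenergic receptor (Homo sapiens) (a higher number here means a weaker inhibitor, a lower number a stronger inhibitor), compound 1 gives 316 nM
- compound 2, `CN(C)CCn1nc(Cc2ccc(Cl)cc2)c2ccccc2c1=O`, in this assay compound 2 gives 158 nM
- compound 3, `CN1CCC(Cn2nc(Cc3ccc(Cl)cc3)c3ccccc3c2=O)C1`, in this assay compound 3 gives 100 nM

Compound 3 has the lowest of the three numbers. Its nearest neighbour is compound 2: a 1.6-fold lower number from compound 2 to compound 3 (0.20 log units; within the scatter), a step that does not stand out from the scatter. Among the compounds with values here, its furthest neighbour is compound 1, whose value of 316 nM lies beyond the usual scatter from the value of compound 3, though no single-point step connects these two.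

Compound 4, `CN1CCC(n2nc(Cc3ccc(Cl)cc3)c3ccccc3c2=O)CC1`, differs from compound 3 in one place: 1-methylpiperidin-4-yl in place of (1-methylpyrrolidin-3-yl)methyl on an aromatic nitrogen. Within the data shown here, the only measured step that bears on this change is the one at the same position, from compound 2 to compound 3, which remained within the scatter. Among the measured compounds shown here, with the same atoms rearranged and only one small step as a guide, no step beyond the scatter is expected in this assay for compound 4, that is, no change at the digits printed from compound 3 to compound 4 (within the scatter). Compound 4 is therefore estimated at 100 nM, with a range from 40 nM to 250 nM.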

Compound 4, inhibition constant: 15.9 nM
Compound 4: the middle estimate sits 6.3-fold (0.80 log units) above what was measured; measured number below the stated range.
By their numbers in this assay, from the lowest: compound 4; then compounds 3, 2 and 1 (each within the scatter of the next, the first and the last beyond it).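

In this assay there is a 6.3-fold lower number from compound 3 to compound 4 (0.80 log units; beyond the scatter), and this exchange of 1-methylpiperidin-4-yl for (1-methylpyrrolidin-3-yl)methyl, with the same atoms joined differently, shows that the group on the aromatic nitrogen can move the number beyond the scatter, which the earlier step at this position did not do. The open-chain 2-(dimethylamino)ethyl group is also separated from the six-membered ring, with a 9.9-fold lower number from compound 2 to compound 4 (1.00 log units; beyond the scatter), so the ring-bearing compound 3 and the open-chain compound 2 both lie beyond the scatter from compound 4. Nothing available explains this difference.

Compound 4 changes both the ring size and the attachment to the aromatic nitrogen, so the compounds shown cannot separate these two changes. Going by these compounds, it remains open how 1-methylpyrrolidin-3-yl directly on the aromatic nitrogen, or (1-methylpiperidin-4-yl)methyl, would read in this assay.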